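Changing the aryl group of compound 1

The source may hold more compounds than are shown below. What is called first, only, known or untested is meant among the compounds shown, and "the series" means these compounds.

In a functional assay on M21 cells (Homo sapiens) for antiproliferative activity, read by sulforhodamine B assay, with a stated time of 48 h (a lower number here means a stronger inhibitor, a higher number a weaker inhibitor), compound 1 `Cc1ccc(NS(=O)(=O)c2ccc(N3CCNC3=O)cc2)cc1` gives 260 nM. Compound 2 `O=C1NCCN1c1ccc(S(=O)(=O)Nc2ccc(I)cc2)cc1` gives 260 nM, so the two stand level. Compound 3 `CC(C)(C)c1ccc(NS(=O)(=O)c2ccc(N3CCNC3=O)cc2)cc1` reads > 1000 nM, which is a limit of the assay and not a number.

Compound 4 `CCc1cccc(NS(=O)(=O)c2ccc(N3CCNC3=O)cc2)c1` has not yet been measured. Its change lies in the group on the sulfonamide nitrogen, where 3-ethylphenyl takes the place of 4-methylphenyl: 3-ethylphenyl in place of 4-methylphenyl on a sulfonamide nitrogen.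

Among the measured compounds shown here, two measured steps bear on this change, since both alter a group on the same aromatic ring. Iodo in place of methyl gives no change at the digits printed from compound 1 to compound 2 (within the scatter). Tert-butyl in place of methyl gives an at least 3.8-fold higher number from compound 1 to compound 3 (0.58 log units; beyond the scatter). So one swap left the number unmoved, while the other raised it beyond the scatter. For the measured compounds named here, no measured compound carries a 3-ethylphenyl group, so these steps offer only loose guidance.

With one silent swap and one costly swap as precedents, a small move toward a higher number in this assay is expected, possibly no larger than the scatter. The estimated change is a 1.5-fold higher number from compound 1 to compound 4 (0.19 log units; within the scatter). For compound 4 the expected value is 400 nM, with an estimated range from 130 nM to 1200 nM.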

Compound 4, half-maximal inhibitory concentration: 82 nM
Beside the measured number, compound 4's estimate is 4.9-fold (0.69 log units) above it; measured number outside the range, below it.
By their numbers in this assay, from the lowest: compound 4; then compounds 1 and 2 (each within the scatter of the next). At a limit, above all of these: compound 3.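

In this assay, earlier swaps on this aryl group had only left the number level or raised it, but 3-ethylphenyl in place of 4-methylphenyl gives a 3.2-fold lower number from compound 1 to compound 4 (0.50 log units; beyond the scatter), and 3-ethylphenyl in place of 4-iodophenyl gives a 3.2-fold lower number from compound 2 to compound 4 (0.50 log units; beyond the scatter). The group on the sulfonamide nitrogen can therefore also move the number down, and compound 4 lies below both compound 1 and compound 2 by more than the scatter. Two things differ at once between compound 1 and compound 4, the place of the group on the ring and the change from methyl to ethyl, so these compounds cannot show which of the two accounts for the lower number.

On these data alone, a 3-methylphenyl or a 4-ethylphenyl group would pull those two changes apart, and what an amine or a carboxylic acid on this ring would do remains open. As far as these compounds go, compound 3 stands only at a limit of the assay and not at a number, so the true size of its steps also stays open: the limit of > 1000 nM in this assay, at which 1 of the 4 values shown sits.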